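This account rests on a few compounds, and the source may have more. Where it says the series, first, only, none or still open, it means among the compounds named here.

Compound 1, `COc1cc(-c2cc(/C=C/C(=O)c3ccc(N)cc3)[nH]n2)cc(OC)c1OC`, and compound 2, `COc1ccc(-c2cc(/C=C/C(=O)c3ccc(N)cc3)[nH]n2)cc1OC`, differ in one place: hydrogen in place of methoxy on an aromatic carbon. In a functional assay on NCI-H522 cells (Homo sapiens) for cytotoxicity, read by sulforhodamine B assay, with a stated time of 48 h, tested at 100 uM (on this read-out higher numbers stand for a weaker effect at the one concentration tested and lower numbers for a stronger effect), compound 1 gives -83%, and compound 2 gives -92%, so the change made a number 9 percentage points lower from compound 1 to compound 2 (within the scatter). Compound 3, `COc1cc(C(=O)/C=C/c2cc(-c3cc(OC)c(OC)c(OC)c3)n[nH]2)cc(OC)c1OC`, is built on a different core; how its core differs from that of compound 1 is not broken down here. In this assay compound 3 gives -98%, a number set apart from that of compound 1 beyond the usual scatter, while its gap to compound 2 stays within it. Going by the values given here, compound 4, `COc1ccc(-c2cc(/C=C/C(=O)c3cc(OC)c(OC)c(OC)c3)[nH]n2)cc1OC`, has not yet been measured; it is related to compound 3 by hydrogen in place of methoxy on an aromatic carbon, the same change in the same surroundings as the one between compound 1 and compound 2. For compound 4 the expected step is a number 1 percentage points higher from compound 3 to compound 4 (within the scatter), since the same change earlier gave a number 9 percentage points lower from compound 1 to compound 2 (within the scatter) and compound 3 already stands at -98%, leaving little room for a lower number. Compound 4 is therefore estimated at -97%, most likely between -100% and -86%.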

Compound 4, a percentage reported as activity, at one concentration (the size of the read-out at that concentration, not a potency): -90%
Estimate against measurement, compound 4: 7 percentage points below; low and high end bracket the measured number.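

Swapping methoxy for hydrogen on an aromatic carbon gave, in this assay, a number 8 percentage points higher from compound 3 to compound 4 (within the scatter). Set beside the earlier step, the same change did not carry over as one fixed shift from the core of compound 1 to the core of compound 3: the same change on two cores in this assay, a number 9 percentage points lower (within the scatter) from compound 1 to compound 2 and a number 8 percentage points higher (within the scatter) from compound 3 to compound 4, 17 percentage points apart, beyond the scatter of two such steps. Each step on its own still lies within the usual scatter, so this does not show that the change truly strengthens the effect on one core and weakens it on the other, and two pairs give no rule for any further core.

The compounds shown carry only methoxy or hydrogen at the changed place, which leaves open how a hydroxyl group, a fluorine atom or a longer alkoxy chain would behave there. On these data alone, each compound was read at a single concentration, which gives no potency, so how these compounds would compare at lower concentrations also stays open.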